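Replacing a Methyl with a Cyanophenyl on the Core

The source may report more compounds than this note shows. Statements on the series, on what has been measured and on what is new or still open speak of the compounds shown alone.

Going by the values given here, compound 1 `Cc1cnc(Nc2cccc(C(=O)N3CCCC3)c2)nc1N[C@H]1[C@@H](C(N)=O)[C@@H]2C=C[C@H]1C2` is the stronger of the two compounds measured so far. In a functional assay on THP-1 cells (Homo sapiens) for inhibition, read by ELISA, with stated times of 1 h and 18 h (a lower number here means a stronger inhibitor, a higher number a weaker inhibitor), compound 1 gives 100 nM, the lowest of the two numbers. Compound 2 `NC(=O)[C@@H]1[C@H](Nc2nc(Nc3cccc(C(=O)N4CCCC4)c3)ncc2-c2ccncc2)[C@H]2C=C[C@@H]1C2` differs from compound 1 only by pyridin-4-yl in place of methyl on an aromatic carbon, and in this assay compound 2 gives 320 nM. That single change is a 3.2-fold higher number from compound 1 to compound 2 (0.51 log units; beyond the scatter). Compound 3 `N#Cc1cccc(-c2cnc(Nc3cccc(C(=O)N4CCCC4)c3)nc2N[C@H]2[C@@H](C(N)=O)[C@@H]3C=C[C@H]2C3)c1` is not yet measured; it differs from compound 1 as follows: 3-cyanophenyl in place of methyl on an aromatic carbon. Among the compounds with values here, the only step that bears on this change is the one from compound 1 to compound 2, in which an aromatic ring also replaced the methyl on an aromatic carbon and the number rose modestly. A similar modest rise is therefore expected here, giving a 3.0-fold higher number from compound 1 to compound 3 (0.48 log units; beyond the scatter). Compound 3 is thus estimated at 300 nM in this assay, with a range from 100 nM to 900 nM.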

Compound 3, half-maximal inhibitory concentration: 280 nM
Compound 3: middle estimate off by 1.1-fold (0.03 log units), on the high side; the measured number falls inside the stated range.
By their numbers in this assay, from the lowest: compound 1; then compounds 3 and 2 (each within the scatter of the next).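

In this assay a second, quite different aromatic ring at this position gives nearly the same picture as the first: the step up from methyl is modest (a 2.8-fold higher number from compound 1 to compound 3 (0.45 log units; beyond the scatter)), and exchanging pyridin-4-yl for 3-cyanophenyl makes no readable difference (a 1.1-fold lower number from compound 2 to compound 3 (0.06 log units; within the scatter)). Across these three compounds, then, both aromatic replacements give a higher number than methyl, and neither the nitrile nor a carbon-only ring in place of the pyridine separates compound 3 from compound 2. No measurement here gives a reason for these steps.

As far as these compounds go, it remains open whether an ethyl chain or a cyclopropyl ring at this position would stay close to methyl or match the aromatic rings. Also open, from the compounds shown here alone, is how a phenyl ring carrying an amine or a carboxylic acid instead of the nitrile would behave.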